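The source may hold more compounds than are shown below. What is called first, only, known or untested is meant among the compounds shown, and "the series" means these compounds.

Compound 1 `COc1ccc(NC(=O)c2ccc3cccc(O)c3n2)cc1` and compound 2 `O=C(Nc1cccc(C(F)(F)F)c1)c1ccc2cccc(O)c2n1` share the same core and differ in a single substituent. In a physicochemical assay for lipophilicity, read by HPLC (a lower number here means a more polar compound, a higher number a more lipophilic compound), compound 1 gives 2.5, and in this assay compound 2 gives 2.5; these two values lie within the scatter of each other, so compound 1 stands level with compound 2. Compound 3 `O=C(Nc1ccc([N+](=O)[O-])cc1)c1ccc2cccc(O)c2n1` carries nitro in place of methoxy on an aromatic carbon. Among the compounds with values here, no measured pair shows this change, so its size is not known from these data. The step from compound 1 to compound 3 is expected to be small and downward, about a number 0.20 log units lower from compound 1 to compound 3 (within the scatter), and barely beyond the scatter. Compound 3 is accordingly estimated at 2.3, between 1.9 and 2.7.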

Compound 3, partition coefficient: 2.5
Beside the measured number, compound 3's estimate is 0.20 log units below it; low and high end bracket the measured number.
By their numbers in this assay, from the lowest: compounds 1, 2 and 3 (each within the scatter of the next).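

Nitro in place of methoxy on an aromatic carbon, para to a large group, gives no change at the digits printed from compound 1 to compound 3 (within the scatter) in this assay, the first step read at this position. For this pair, then, the reading does not separate a methoxy from a nitro at this place. Nothing shown gives a reason for this result. The compounds shown leave open whether an amine, a carboxylic acid or a longer chain at this place would also read level with compound 1 in this assay.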